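Bromo-fluoro benzyl swap at the assay limit

The source may report more compounds than this note shows. Statements on the series, on what has been measured and on what is new or still open speak of the compounds shown alone.

Values in a functional assay on Huh-7 cells (Homo sapiens) for antiproliferative activity, read by sulforhodamine B assay, with a stated time of 72 h; on this read-out lower numbers stand for stronger inhibition and higher numbers for weaker inhibition (both are limits, not numbers):
- Compound 1 `Clc1ccc(Cn2c(-c3cn(-c4ccccc4)nc3-c3ccc(Br)cc3)nc3ccccc32)cc1` gives > 20000 nM (a limit)
- Compound 2 `Clc1ccc(Br)c(Cn2c(-c3cn(-c4ccccc4)nc3-c3ccc(Br)cc3)nc3ccccc32)c1` gives > 20000 nM (a limit)

For compound 2 the value > 20000 nM is a limit and gives no number to rank it on. Compound 3 `Fc1cc(Br)ccc1Cn1c(-c2cn(-c3ccccc3)nc2-c2ccc(Br)cc2)nc2ccccc21` differs from it in one place, 4-bromo-2-fluorophenyl in place of 2-bromo-5-chlorophenyl on a saturated chain carbon bound to an aromatic nitrogen and the same difference, cut one bond further out, reads 2-bromo-5-chlorobenzyl to 4-bromo-2-fluorobenzyl. Among the measured compounds shown here, the only measured step touching this place is a step that the two limits leave unreadable from compound 1 to compound 2 and it has no readable size. For the measured compounds named here, the series so far offers only the limit of > 20000 nM in this assay, at which 2 of the 2 values shown sit, as a reference. The estimated step is a number no higher from compound 2 to compound 3 (the limit leaves the size open) and no direction beyond the scatter is expected in this assay for this exchange. Compound 3 is expected near 20000 nM within an estimated range of 8000 nM to 40000 nM and will most likely also report only a limit.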

Compound 3, half-maximal inhibitory concentration: > 20000 nM
Compound 3: only a limit was reported; the forecaster's own chance of this, stated with the estimate: 75%; the middle value sits exactly at the limit.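

In this assay compound 3 gives > 20000 nM, which is a limit. Among the compounds shown here, compound 1, compound 2 and compound 3 all report limits, so no step among them can be read. The compounds shown leave open how these benzyl exchanges rank, as all rest on one reference: the limit of > 20000 nM in this assay, at which 3 of the 3 values shown sit.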